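The source may hold more compounds than are shown below. What is called first, only, known or untested is meant among the compounds shown, and "the series" means these compounds.

Compound 1 `CCOC(=O)c1c(-c2ccc(OC)cc2)[nH]c2cccc(OC)c2c1=O` is one of three compounds sharing a core that have been measured in a physicochemical assay for solubility, in phosphate buffer, at pH 7.4; on this read-out lower numbers stand for lower solubility and higher numbers for higher solubility. In this assay compound 1 gives > 100000 nM, which is a limit of the assay rather than a number. Compound 2 `CCOC(=O)c1c(-c2cccc(OC)c2)[nH]c2cccc(OC)c2c1=O` gives > 100000 nM, also a limit. Compound 3 `CCOC(=O)c1c(-c2ccccc2Cl)[nH]c2cccc(OC)c2c1=O` gives > 100000 nM, again a limit. Compound 1 therefore sits at the limit of > 100000 nM in this assay, at which 3 of the 3 values shown sit, and where it stands relative to the other two cannot be read. The steps a step that the two limits leave unreadable from compound 1 to compound 2 and a step that the two limits leave unreadable from compound 1 to compound 3 are unreadable for the same reason, as is a step that the two limits leave unreadable from compound 2 to compound 3.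

Compound 4 `CCOC(=O)c1c(-c2ccc(C(F)(F)F)cc2)[nH]c2cccc(OC)c2c1=O` has not yet been measured. It differs from compound 1 by trifluoromethyl in place of methoxy on an aromatic carbon. Within the data shown here, none of the measured steps bears directly on this change: all three exchange one whole aromatic substituent for another on an aromatic carbon, and none of them yields a readable size. The expectation thus rests only on the level at which the three values sit, with no anchor for the direction or size of the step.

Compound 4 is expected to give 50000 nM, within 10000 nM to 150000 nM. That estimate corresponds to an expected step of an at least 2.0-fold lower number from compound 1 to compound 4 (0.30 log units; that floor lies within the scatter), counted from a starting point that is itself a limit.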

Compound 4, solubility: 22000 nM
The estimate for compound 4 lay 2.3-fold (0.36 log units) above the measured number; measured number inside the range.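

Trifluoromethyl in place of methoxy, on an aromatic carbon para to a large group, gives an at least 4.5-fold lower number from compound 1 to compound 4 (0.65 log units; beyond the scatter) in this assay, the first step in this series with a readable direction and a size beyond the scatter. Among these compounds, the earlier exchanges among compound 1, compound 2 and compound 3 all remain unreadable, so this change is the first to show that a substituent on this aryl group can bring the read-out down to a measurable number. Compound 4 is the only one of the four to give such a number, while the other three stay at the shared ceiling: the limit of > 100000 nM in this assay, at which 3 of the 4 values shown sit.

As far as these compounds go, the full size of the step stays open, as its starting point in compound 1 is only a limit and the step gives a floor rather than a measured distance. Also open, from the compounds shown here alone, is how other groups on this same aromatic carbon would read, such as a nitrile, an amine, a carboxylic acid or a longer alkoxy chain, and whether any of them would stay at the limit or fall from it as trifluoromethyl does.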